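The source may hold more compounds than are shown below. What is called first, only, known or untested is meant among the compounds shown, and "the series" means these compounds.

Compound 1 `COc1ccc(NC(=O)Cn2nc(Cc3ccccc3)c3ccccc3c2=O)cc1`: 62000 nM
Compound 2 `O=C(Cn1nc(Cc2ccccc2)c2ccccc2c1=O)Nc1ccccc1Cl`: 89000 nM
Compound 3 `O=C(Cn1nc(Cc2ccccc2)c2ccccc2c1=O)Nc1cccc(Cl)c1`: 10800 nM

These three compounds share a core and differ only in the aromatic group on an amide-type nitrogen. All were tested in a functional assay on MCF7 cells (Homo sapiens) for antiproliferative activity, read by sulforhodamine B assay, with a stated time of 72 h; a lower number here means a stronger inhibitor, a higher number a weaker inhibitor. Compound 3 has the lowest number of the three. Its gaps to the other two lie beyond the scatter: a 5.7-fold lower number from compound 1 to compound 3 (0.76 log units; beyond the scatter), and an 8.2-fold lower number from compound 2 to compound 3 (0.92 log units; beyond the scatter). The other two sit close together, with a 1.4-fold higher number from compound 1 to compound 2 (0.16 log units; within the scatter).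

The next compound, compound 4 `O=C(Cn1nc(Cc2ccccc2)c2ccccc2c1=O)Nc1ccc(Cl)cc1`, has not yet been measured. It has 4-chlorophenyl in place of 3-chlorophenyl on an amide-type nitrogen.

Within the data shown here, no measured compound carries this group, so the evidence is indirect. Among the measured compounds shown here, the closest precedent is the only measured swap between two chlorophenyl groups, an 8.2-fold lower number from compound 2 to compound 3 (0.92 log units; beyond the scatter), which shows that the chlorine's place on the ring can change the number beyond the scatter. Compound 1, the only one carrying a 4-substituted phenyl, gives 62000 nM, also well short of compound 3. A modest rise therefore seems likely, though three compounds are a thin basis. The expected step is a 2.8-fold higher number from compound 3 to compound 4 (0.44 log units; beyond the scatter). Compound 4 is estimated at 30000 nM, within a range of 9000 nM to 85000 nM.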

Compound 4, half-maximal inhibitory concentration: 13000 nM
The estimate for compound 4 lay 2.3-fold (0.36 log units) above the measured number; low and high end bracket the measured number.
By their numbers in this assay, from the lowest: compounds 3 and 4 (each within the scatter of the next); then compounds 1 and 2 (each within the scatter of the next).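

In this assay, exchanging the 3-chlorophenyl group for the 4-chlorophenyl group on the amide-type nitrogen makes no readable difference (a 1.2-fold higher number from compound 3 to compound 4 (0.08 log units; within the scatter)), so the low number of compound 3 does not depend on that one chlorine placement alone. The 2-chlorophenyl group now stands apart from both of the other chlorophenyl groups (a 6.8-fold lower number from compound 2 to compound 4 (0.84 log units; beyond the scatter)), which means that among these three compounds, chlorine placement matters only for compound 2, not as a steady trend around the ring. Among these compounds, this result also gives the first comparison of two different groups at the same printed ring position. The 4-methoxyphenyl and 4-chlorophenyl compounds differ only in chloro in place of methoxy on an aromatic carbon (a 4.8-fold lower number from compound 1 to compound 4 (0.68 log units; beyond the scatter)), so the identity of the group counts as well as its placement.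

No measurement shown offers an explanation for why these numbers differ. As far as these compounds go, it remains open whether fluoro, bromo or trifluoromethyl on the phenyl ring would match chloro, and whether a pyridyl ring or a benzyl group on the same nitrogen would keep numbers like those of compound 3 and compound 4.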